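Swapping the Amide Headgroup in a Sulfonyl Tetralin Series

A few compounds are considered here, and "the series" means these few. Any claim that something is new, unique, unknown or untested is made for them only; others in the source may bear on it.

Of the compounds shown here, two have been measured so far in an assay on isolated protein for displacement of a labelled ligand from 5-hydroxytryptamine receptor 6 (Homo sapiens); a higher number here means a weaker inhibitor, a lower number a stronger inhibitor. Compound 1 `N#Cc1cccc(S(=O)(=O)c2ccc3c(c2)CCC[C@H]3C=N)c1` gives 0.501 nM. Compound 2 `O=C(NC[C@@H]1CCCc2cc(S(=O)(=O)c3cccc(F)c3)ccc21)c1ncc[nH]1` gives 15.9 nM, the highest of the two numbers and therefore the weaker binder of the pair; the gap between them lies well beyond the usual scatter. Compound 3 `CNCC(=O)NC[C@@H]1CCCc2cc(S(=O)(=O)c3cccc(F)c3)ccc21` has not been measured. It differs from compound 2 in a single place: (methylamino)methyl in place of 1H-imidazol-2-yl on a carbonyl carbon. The shared core, the sulfonyl link and the fluorophenyl group stay untouched; only the group attached to the carbonyl carbon changes. Among the compounds with values here, no measured pair shows this kind of swap, so there is no direct guide to its effect. The change is expected to produce only a small step, a 1.3-fold higher number from compound 2 to compound 3 (0.10 log units; within the scatter), not clearly beyond the scatter. Compound 3 is therefore estimated at 20 nM, with a range from 5 nM to 80 nM.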

Compound 3, inhibition constant: 0.159 nM
The estimate for compound 3 lay 130-fold (2.10 log units) above the measured number; measured number below the stated range.
By their numbers in this assay, from the lowest: compound 3; then compound 1; then compound 2.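

In this assay the group on the carbonyl carbon proves to matter a great deal: (methylamino)methyl in place of 1H-imidazol-2-yl gives a 100-fold lower number from compound 2 to compound 3 (2.00 log units; beyond the scatter) and so counts as a large step. The two groups have the same number of hydrogen-bond donors and acceptors and neither has a net charge, so these counts do not separate them, whereas the ring and the number of heavy atoms do differ. Nothing available here accounts for the size of this step.

As far as these compounds go, it remains open whether the nitrogen of the new group is needed, which a plain ethyl or a hydroxymethyl group on the same carbonyl carbon could show. Also open, from the compounds shown here alone, is how a longer chain, such as 2-(methylamino)ethyl, or a dimethylamino end would fare at this position.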